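From a Propargyloxyphenyl to a Fluorophenyl Chain End

The compounds below may be only part of what the source reports. "The series", "measured", "known", "first", "only" and "open" are said of these compounds alone.

Of the compounds shown here, three sharing one core have been measured in a functional assay on B16 cells (Mus musculus) for cytotoxicity, read by MTT assay, with a stated time of 72 h; on this read-out higher numbers stand for weaker inhibition and lower numbers for stronger inhibition. Compound 1 `COc1cc(C(=O)c2cc(OC)c(OC)c(OC)c2)cc(NC(=O)/C=C/c2cc(OC)c(OC)c(OC)c2)c1OC` gives 2500 nM. Compound 2 `COc1ccc(/C=C/C(=O)Nc2cc(C(=O)c3cc(OC)c(OC)c(OC)c3)cc(OC)c2OC)cc1OC` gives 1300 nM. Compound 3 `C#CCOc1cccc(/C=C/C(=O)Nc2cc(C(=O)c3cc(OC)c(OC)c(OC)c3)cc(OC)c2OC)c1` gives 5100 nM, the highest of the three numbers: the step of a 2.0-fold higher number from compound 1 to compound 3 (0.31 log units; beyond the scatter) and the step of a 3.9-fold higher number from compound 2 to compound 3 (0.59 log units; beyond the scatter) both lie beyond the scatter, whereas a 1.9-fold lower number from compound 1 to compound 2 (0.28 log units; within the scatter) does not. Compound 4 `COc1cc(C(=O)c2cc(OC)c(OC)c(OC)c2)cc(NC(=O)/C=C/c2ccc(F)cc2)c1OC` has not yet been measured. It differs from compound 3 in one place: 4-fluorophenyl in place of 3-(propargyloxy)phenyl on a double-bonded chain carbon bound to a double-bonded chain carbon. For the measured compounds named here, no measured step puts a 4-fluorophenyl onto this chain carbon, so the only guidance comes from the two steps that brought the propargyloxyphenyl in, each of which raised the number modestly. Removing that group again is expected to give back part of that change. The fluorophenyl, however, carries none of the methoxy groups seen in compounds 1 and 2, which gave the lowest numbers. The expected step is therefore a 1.7-fold lower number from compound 3 to compound 4 (0.23 log units; within the scatter), a modest fall at most. Compound 4 is estimated at 3000 nM, with a range from 1000 nM to 9000 nM.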

Compound 4, half-maximal inhibitory concentration: 900 nM
Beside the measured number, compound 4's estimate is 3.3-fold (0.52 log units) above it; measured number outside the range, below it.
By their numbers in this assay, from the lowest: compounds 4, 2 and 1 (each within the scatter of the next, the first and the last beyond it); then compound 3.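

This chain carbon turns out to accept an end ring with no methoxy group at all in this assay: there is a 2.8-fold lower number from compound 1 to compound 4 (0.44 log units; beyond the scatter), and a 1.4-fold lower number from compound 2 to compound 4 (0.16 log units; within the scatter), so compound 2 and compound 4 cannot be told apart. Lacking methoxy groups therefore does not by itself raise the number, since neither compound 3 nor compound 4 carries one on this ring, and yet there is a 5.7-fold lower number from compound 3 to compound 4 (0.75 log units; beyond the scatter). What lies behind that step has no measured support here.

A plain phenyl, or a ring carrying a chlorine, an amine or a carboxylic acid, on this chain carbon would show whether the fluorine itself matters or simply the loss of the propargyloxy group. From the compounds shown here alone, whether these steps hold in other cell types also stays open.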